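A Ring-Bearing Group Replaces an Open Chain on Compound 3

The source may report more compounds than this note shows. Statements on the series, on what has been measured and on what is new or still open speak of the compounds shown alone.

Of the compounds shown here, three sharing one core have been tested in a functional assay on the whole organism (strain Wistar) for inhibition, with Rattus norvegicus as the target, read by paw edema, with stated times of 30 min and 3 h, at a dose of 20 mg/kg; a lower number here means less inhibition, a higher number more inhibition at the dose given (going by the name of the read-out). Compound 1 `CCOC(=O)C1=C(C)NC(C)=C(C(=O)OCC)C1c1ccc(OCC(=O)Nc2nc3ccccc3s2)cc1` gives 65.9%, compound 2 `CCOC(=O)C1=C(C)NC(C)=C(C(=O)OCC)C1c1ccc(OCC(=O)NNC(=O)c2ccsc2Cl)cc1` gives 53.3%, and compound 3 `CCOC(=O)C1=C(C)NC(C)=C(C(=O)OCC)C1c1ccc(OCC(=O)NNC(=O)CCC(=O)O)cc1` gives 56.9%. Among the measured compounds shown here, compound 3 thus stands second highest of the three, with compound 2 nearest and compound 1 furthest, both within the scatter; the only step beyond it is a number 12.6 percentage points lower from compound 1 to compound 2 (beyond the scatter).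

Compound 4 `CCOC(=O)C1=C(C)NC(C)=C(C(=O)OCC)C1c1ccc(OCC(=O)NN2C(=O)c3ccccc3C2=O)cc1` differs from compound 3 by a group of 11 heavy atoms (8 carbon, 1 nitrogen, 2 oxygen; one five-membered non-aromatic ring with 1 hetero atom, one six-membered aromatic ring of carbon only) in place of a group of 8 heavy atoms (4 carbon, 1 nitrogen, 3 oxygen; no ring), on an amide-type nitrogen. The step of a number 9 percentage points lower from compound 1 to compound 3 (within the scatter) and the step of a number 3.6 percentage points higher from compound 2 to compound 3 (within the scatter) both swap what hangs on that same amide-type nitrogen and both stay within the scatter, so exchanging this tail has so far moved this assay little. Compound 4 carries a group with two rings and no hydrogen-bond donors, unlike the open chain it replaces, but the measured steps give no sign that this matters. Compound 4 is therefore expected to give 57%, in a range from 45% to 68%. This expectation amounts to a number 0.1 percentage points higher from compound 3 to compound 4 (within the scatter), within the scatter.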

Compound 4, a percentage reported as inhibition, in the whole organism at one dose (the size of the read-out at that dose, not a potency): 59.3%
For compound 4 the middle estimate is 2.3 percentage points below the measured one, and the stated range covers the measured number.
By their numbers in this assay, from the lowest: compounds 2, 3, 4 and 1 (each within the scatter of the next, the first and the last beyond it).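

Swapping the open chain on the amide-type nitrogen for the ring-bearing group gives a number 2.4 percentage points higher from compound 3 to compound 4 (within the scatter) in this assay and so leaves the result within the scatter, even though the new tail has rings and no hydrogen-bond donors. Set against the two other tails, the same group gives a number 6 percentage points higher from compound 2 to compound 4 (within the scatter) and a number 6.6 percentage points lower from compound 1 to compound 4 (within the scatter) and so sits within the scatter of both compounds, although they are separated by a number 12.6 percentage points lower from compound 1 to compound 2 (beyond the scatter). Nothing measured here explains why these tails stay so close.

A plain methyl group or a longer alkyl chain without any ring on this nitrogen would test whether the tail needs to be this large at all. Readings at a single dose also leave open whether these tails would separate at other doses.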